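Alkyne terminus change in the nitro series: cytotoxicity notes

This account rests on a few compounds, and the source may have more. Where it says the series, first, only, none or still open, it means among the compounds named here.

Measured in an ADME assay on CHO cells (Cricetulus griseus) for cytotoxicity, read by MTT assay, with a stated time of 24 h; on this read-out lower numbers stand for higher toxicity in this test and higher numbers for lower toxicity in this test:
compound 1 `Cc1ccc(C#Cc2c([N+](=O)[O-])nc3n2CC(C)O3)cc1` gives 5470 nM
compound 2 `CC1Cn2c(nc([N+](=O)[O-])c2C#Cc2ccc(C(C)(C)C)cc2)O1` gives 6620 nM

Compound 1 stands at the lowest of the two numbers in this assay. For the measured compounds named here, its only neighbour is compound 2, reached by a 1.2-fold higher number from compound 1 to compound 2 (0.08 log units; within the scatter); the two values therefore do not separate from each other, and no order can be read between them.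

Compound 3 `CC1Cn2c(nc([N+](=O)[O-])c2C#COC2CCCC2)O1` has not yet been measured in this assay. It differs from compound 1 by cyclopentyloxy in place of 4-methylphenyl on a triple-bonded carbon. Going by the values given here, the one measured step, tert-butyl in place of methyl on an aromatic carbon, alters only a substituent on the 4-methylphenyl group that leaves in compound 3 and was itself within the scatter; no measured step in this assay covers the exchange of an aromatic group for an alkoxy group at a triple-bonded carbon. Among the compounds with values here, with no step of that kind available, the expectation for compound 3 rests on compound 1 alone and is a step of a 1.1-fold higher number from compound 1 to compound 3 (0.04 log units; within the scatter) that stays within the scatter, with a wide range to reflect the missing precedent. Compound 3 is therefore estimated at 6000 nM, ranging from 2000 nM to 20000 nM.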

Compound 3, half-maximal cytotoxic concentration: 6650 nM
The estimate for compound 3 lay 1.1-fold (0.04 log units) below the measured number; the measured number falls inside the stated range.
By their numbers in this assay, from the lowest: compounds 1, 2 and 3 (each within the scatter of the next).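

In this assay, the exchange at the triple-bonded carbon goes further than the earlier tert-butyl for methyl swap, which only touched a substituent on the aromatic group: the whole 4-methylphenyl leaves and cyclopentyloxy enters, and the result is a 1.2-fold higher number from compound 1 to compound 3 (0.08 log units; within the scatter). This position therefore carries either a six-membered aromatic ring of carbon only or a five-membered non-aromatic ring joined through oxygen, with one hydrogen-bond acceptor added, and the two compounds do not separate on this read-out. No supporting measurement is available to account for this result.

Still open, from the compounds shown here alone, is whether any group on the triple-bonded carbon gives a step beyond the scatter, for example a basic amine such as a piperidine, a carboxylic acid, or a longer straight alkoxy chain in place of cyclopentyloxy. Equally open, going by these compounds, is whether the same exchange would also stay within the scatter on a core carrying something other than the nitro group, since both members of this pair share that core.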